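Swapping Fluoro for Methyl at Two Different Places

The source may report more compounds than this note shows. Statements on the series, on what has been measured and on what is new or still open speak of the compounds shown alone.

Compound 1 `NS(=O)(=O)c1ccc(Nc2ncc(F)c(Nc3nc4ccc(Cl)cc4s3)n2)cc1` and compound 2 `Cc1cnc(Nc2ccc(S(N)(=O)=O)cc2)nc1Nc1nc2ccc(Cl)cc2s1` share one core. In a functional assay on HCT-116 cells (Homo sapiens) for antiproliferative activity, read by MTT assay, with a stated time of 48 h (a higher number here means a weaker inhibitor, a lower number a stronger inhibitor), compound 1 gives 8620 nM, and compound 2 gives 2520 nM. The change between them is methyl in place of fluoro on an aromatic carbon, sitting on a six-membered aromatic ring with 2 nitrogen, ortho to a large group, two atoms from the ring nitrogen and para to a large group, and it made a 3.4-fold lower number from compound 1 to compound 2 (0.53 log units; beyond the scatter). Compound 3 `NS(=O)(=O)c1ccc(Nc2nccc(Nc3nc4ccc(F)cc4s3)n2)cc1` carries a core whose difference from compound 1 is not broken down here; in this assay compound 3 gives 700 nM. Compound 4 `Cc1ccc2nc(Nc3ccnc(Nc4ccc(S(N)(=O)=O)cc4)n3)sc2c1` differs from compound 3 by methyl in place of fluoro on an aromatic carbon, the same kind of change but placed on a six-membered aromatic ring of carbon only, part of a fused system of two rings, meta to a fused ring and para to a fused ring. Resting on the earlier step of a 3.4-fold lower number from compound 1 to compound 2 (0.53 log units; beyond the scatter) at a different place, compound 4 is expected to show a smaller step of a 1.2-fold lower number from compound 3 to compound 4 (0.07 log units; within the scatter). Compound 4 is estimated at 600 nM, between 200 nM and 2000 nM.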

Compound 4, half-maximal inhibitory concentration: 900 nM
Compound 4: middle estimate off by 1.5-fold (0.18 log units), on the low side; the measured number falls inside the stated range.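

In this assay, putting methyl in place of fluoro on the ring of carbon only gives a 1.3-fold higher number from compound 3 to compound 4 (0.11 log units; within the scatter), so compound 3 and compound 4 cannot be told apart. The same kind of swap therefore did not carry over from one core to the other with the same size: the same change on two cores in this assay, a 3.4-fold lower number (0.53 log units; beyond the scatter) from compound 1 to compound 2 and a 1.3-fold higher number (0.11 log units; within the scatter) from compound 3 to compound 4, 4.4-fold (0.64 log units) apart, beyond the scatter of two such steps

This shows that the earlier step cannot simply be transferred, but it does not show whether the core or the place of the swap accounts for the gap, since the two pairs differ in both.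

As far as these compounds go, it remains open how a methoxy or an amine would behave in place of the fluoro of compound 3. From the compounds shown here alone, whether the swap would give a step beyond the scatter on any further core also remains open.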